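Bromo to Chloro on the Fused Ring of Compound 2

The compounds below may be only part of what the source reports. "The series", "measured", "known", "first", "only" and "open" are said of these compounds alone.

Two compounds have numbers in a functional assay on cells (Cancer cell lines, Homo sapiens) for cytotoxicity, read by sulforhodamine B assay, with a stated time of 48 h; on this read-out lower numbers stand for stronger inhibition of growth and higher numbers for weaker inhibition of growth. Compound 1 `COc1ccc(C2CC(c3ccccc3)=NN2C2=NC(=O)/C(=C3\C(=O)Nc4ccc(Br)cc43)S2)cc1` gives 200 nM in this assay. Compound 2 `COc1ccc(-c2cc(-c3ccc(Cl)cc3)n(C3C(=O)Nc4ccc(Br)cc43)n2)cc1` gives 7530 nM in this assay, the highest of the two numbers; its gap to compound 1 lies beyond the scatter, and the two compounds differ in more than one place, so what separates them cannot be assigned to a single change. Compound 3 `COc1ccc(-c2cc(-c3ccc(Cl)cc3)n(C3C(=O)Nc4ccc(Cl)cc43)n2)cc1` has not been measured. It differs from compound 2 by chloro in place of bromo on an aromatic carbon. Among the measured compounds shown here, no step of this kind between measured compounds is available. The expected step from compound 2 to compound 3 in this assay is a 1.1-fold lower number from compound 2 to compound 3 (0.03 log units; within the scatter), small and not beyond the scatter. Compound 3 is therefore estimated at 7000 nM in this assay, within a range from 3000 nM to 16000 nM.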

Compound 3, concentration for 50% growth inhibition: 4370 nM
Estimate against measurement, compound 3: 1.6-fold (0.20 log units) above, within the range that was stated.
By their numbers in this assay, from the lowest: compound 1; then compounds 3 and 2 (each within the scatter of the next).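

In this assay, among the compounds shown here, chloro in place of bromo on an aromatic carbon gives a 1.7-fold lower number from compound 2 to compound 3 (0.24 log units; within the scatter), and this is the first comparison here between compounds that differ in one place. At this site on the six-membered aromatic ring, part of a fused system of two rings, the exchange of one halogen for the other therefore stays within the scatter, so the read-out does not separate compound 2 from compound 3. No independent measurement bears on this result.

The compounds shown leave open what a group of another kind, such as an amine or a carboxylic acid, would do at this aromatic carbon. They also leave unassigned what separates compound 1 from compound 2, since those two differ in more than one place.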